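This account rests on a few compounds, and the source may have more. Where it says the series, first, only, none or still open, it means among the compounds named here.

Compounds measured in a functional assay on MCF7 cells (Homo sapiens) for inhibition; on this read-out higher numbers stand for weaker inhibition of growth and lower numbers for stronger inhibition of growth:
compound 1, `COc1cc(/C=C/C(=O)c2cccc(-n3cc(-c4ccc(Cl)cc4)[nH]c3=O)c2)ccc1O`, gives 2300 nM;
compound 2, `COc1cc(/C=C/C(=O)c2cccc(-n3cc(-c4ccccc4)[nH]c3=O)c2)cc(OC)c1OC`, gives 310 nM.

Of these two numbers, compound 1 stands at the highest; compound 2 is the nearer one and its number is lower, by a gap that lies beyond the scatter. The two compounds differ in more than one place, so the two values alone show this and nothing more about which part of the structure is responsible.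

Compound 3, `COc1cc(/C=C/C(=O)c2cccc(-n3cc(-c4ccccc4)[nH]c3=O)c2)ccc1O`, has not yet been measured in this assay . It differs from compound 1 in one place:

hydrogen in place of chloro on an aromatic carbon

Among the measured compounds shown here, since no single-change step is on hand that would show what the loss of the chloro does here, the expectation is a small change, if any. Compound 3 is expected to land at 1600 nM, within 500 nM to 5000 nM, which would make the step of a 1.4-fold lower number from compound 1 to compound 3 (0.16 log units; within the scatter) one within the scatter of this assay .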

Compound 3, concentration for 50% growth inhibition: 1550 nM
Estimate against measurement, compound 3: 1.0-fold (0.01 log units) above; measured number inside the range.
By their numbers in this assay, from the lowest: compound 2; then compounds 3 and 1 (each within the scatter of the next).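

In this assay, the exchange of chloro for hydrogen on an aromatic carbon, para to a large group, gives a 1.5-fold lower number from compound 1 to compound 3 (0.17 log units; within the scatter), the only single-change step shown here. For this one pair, going from 4-chlorophenyl to phenyl on the shared core therefore produces no difference that this read-out can separate from the scatter of repeated measurements, something the earlier pair of compounds, which differ in more than one place, could not show. No measurement on hand offers an explanation of this result.

As far as these compounds go, it remains open whether an amine, a carboxylic acid or a methoxy group at the same position would also stay within the scatter. The compounds shown also leave open whether the same exchange of chloro for hydrogen would give a similar step on a core carrying other groups.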